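This account rests on a few compounds, and the source may have more. Where it says the series, first, only, none or still open, it means among the compounds named here.

Measured in an ADME assay on WI-38 cells (Homo sapiens) for cytotoxicity, read by MTT assay, with a stated time of 72 h; on this read-out higher numbers stand for weaker inhibition and lower numbers for stronger inhibition:
- Compound 1 `COc1cc(OC)cc(-c2cccc(NC(=O)CCc3cccc4c3B(O)OC4)c2)c1`: 1700 nM
- Compound 2 `COc1cc(OC)cc(-c2cccc(NC(=O)CCc3ccc4c(c3)COB4O)c2)c1`: > 100000 nM (a limit)
- Compound 3 `COc1cccc(-c2cccc(NC(=O)CCc3ccccc3)c2)c1`: > 100000 nM (a limit)

Compound 3 gives no number in this assay, only the limit > 100000 nM. Compound 4 `COc1cc(OC)cc(-c2cccc(NC(=O)CCc3ccccc3)c2)c1` differs from it by a single change: methoxy in place of hydrogen on an aromatic carbon. Going by the values given here, no measured step covers this change. The only one, an at least 58-fold higher number from compound 1 to compound 2 (1.76 log units; beyond the scatter), concerns the boron-bearing group, which compound 4 lacks, so it bears on the question only weakly. Compound 4 keeps the methoxy groups found in compound 2, and compound 2 reports only the limit > 100000 nM. The expected change is none beyond the scatter: a number no higher from compound 3 to compound 4 (the limit leaves the size open). Compound 4 is estimated at 100000 nM, with an expected range of 30000 nM to 300000 nM, and will most likely be reported as a limit again.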

Compound 4, half-maximal inhibitory concentration: > 100000 nM
Compound 4 gave a limit, no number; the forecaster's own chance of this, stated with the estimate: 75%; the middle value sits exactly at the limit.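

In this assay compound 4 gives only a limit, > 100000 nM. The boron-bearing group of compound 1 replaced by a six-membered aromatic ring of carbon only gives an at least 58-fold higher number from compound 1 to compound 4 (1.76 log units; beyond the scatter), so on the dimethoxy-bearing core, a number appears only with compound 1. The steps into compound 4 from compound 2 and from compound 3 cannot be read, and the added methoxy shows no effect that can be read: the limit of > 100000 nM in this assay, at which 3 of the 4 values shown sit.

From the compounds shown here alone, whether the methoxy changes anything beyond that limit stays open. So does whether an amine or a carboxylic acid in place of the boron-bearing group would give a number.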